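The source may hold more compounds than are shown below. What is called first, only, known or untested is meant among the compounds shown, and "the series" means these compounds.

Two amides of the shared core have values in a functional assay on MV4-11 cells (Homo sapiens) for inhibition, read by luminescence, with a stated time of 3 days; on this read-out higher numbers stand for weaker inhibition of growth and lower numbers for stronger inhibition of growth. Compound 1 (`CC[C@@H]1CC[C@@H](C(=O)N2CCN(C(C)=O)CC2)N1C(=O)C1=C(C(C)C)N2C(=N[C@@](C)(c3ccc(Cl)cc3)[C@H]2c2ccc(Cl)cc2)S1`) gives 130 nM, and compound 2 (`CC[C@@H]1CC[C@@H](C(=O)N2CCN(C)[C@H](C)C2)N1C(=O)C1=C(C(C)C)N2C(=N[C@@](C)(c3ccc(Cl)cc3)[C@H]2c2ccc(Cl)cc2)S1`) gives 110 nM. These two values lie within the scatter of each other, so compound 2 stands level with compound 1. Compound 3 (`CC[C@@H]1CC[C@@H](C(=O)N2CCN(C)[C@@H](C)C2)N1C(=O)C1=C(C(C)C)N2C(=N[C@@](C)(c3ccc(Cl)cc3)[C@H]2c2ccc(Cl)cc2)S1`) is related to compound 2 as follows: the two compounds have the same atoms and bonds and differ only in configuration as drawn: 1 of 5 stereo elements differ; a stereocentre at a saturated ring carbon is drawn R in compound 2 and S in compound 3. For the measured compounds named here, only one measured step bears on this, and only indirectly. That step, a 1.2-fold lower number from compound 1 to compound 2 (0.07 log units; within the scatter), puts 3,4-dimethylpiperazin-1-yl in place of 4-acetylpiperazin-1-yl on a carbonyl carbon and stays within the scatter. Going by the values given here, no measured pair differs in configuration alone, so the effect of this inversion is untested. No step beyond the scatter is expected in this assay, and neither direction is favoured. The expected step is a 1.1-fold higher number from compound 2 to compound 3 (0.04 log units; within the scatter). For compound 3 the estimate is 120 nM, with an expected range from 50 nM to 300 nM.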

Compound 3, concentration for 50% growth inhibition: 250 nM
Beside the measured number, compound 3's estimate is 2.1-fold (0.32 log units) below it; the range from low to high includes it.
By their numbers in this assay, from the lowest: compounds 2, 1 and 3 (each within the scatter of the next, the first and the last beyond it).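

In this assay the configuration at this saturated ring carbon of the 3,4-dimethylpiperazin-1-yl amide is not neutral: going from R to S gives a 2.3-fold higher number from compound 2 to compound 3 (0.36 log units; beyond the scatter). For the compounds shown here, this modest step is the first beyond the scatter, and it can be assigned to this one stereocentre because nothing else separates the pair: the fact that compounds 2 and 3 differ only in the configuration as drawn. Against the 4-acetylpiperazin-1-yl amide, the S form gives a 1.9-fold higher number from compound 1 to compound 3 (0.28 log units; within the scatter), so exchanging that group stays inside the scatter with either configuration.

From the compounds shown here alone, it remains open whether the gap between R and S persists when this ring methyl is replaced by an ethyl or hydroxymethyl group. Going by these compounds, it is also open how an unsubstituted piperazine amide, with no stereocentre at this carbon, compares with the two forms.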